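The source may report more compounds than this note shows. Statements on the series, on what has been measured and on what is new or still open speak of the compounds shown alone.

Cytotoxicity notes on the series. Compound 1 `CNCc1cc(N)c(Nc2ccc(C#N)cc2)cc1Oc1c(C)cc(C#N)cc1C` gives 12700 nM in an ADME assay on MT2 cells (Homo sapiens) for cytotoxicity; on this read-out higher numbers stand for lower toxicity in this test and lower numbers for higher toxicity in this test. Compound 2 `Cc1cc(C#N)cc(C)c1Oc1cc(Nc2ccc(C#N)cc2)c(N)cc1CNCCCO` gives 15100 nM, a step of a 1.2-fold higher number from compound 1 to compound 2 (0.08 log units; within the scatter). Compound 3 `Cc1cc(C#N)cc(C)c1Oc1cc(Nc2ccc(C#N)cc2)c(N)cc1CN1CCN(C)CC1` gives 96900 nM and stands highest of the three numbers, with compound 2 nearest and compound 1 furthest, both gaps beyond the scatter. Compound 4 `Cc1cc(C#N)cc(C)c1Oc1cc(Nc2ccc(C#N)cc2)c(N)cc1COC(C)C` is not yet measured. The change from compound 3 to compound 4 is isopropoxy in place of 4-methylpiperazin-1-yl on a saturated chain carbon bound to an aromatic carbon. Among the compounds with values here, the steps that bear on it both end at compound 3: a 7.6-fold higher number from compound 1 to compound 3 (0.88 log units; beyond the scatter) and a 6.4-fold higher number from compound 2 to compound 3 (0.81 log units; beyond the scatter); in each the 4-methylpiperazin-1-yl group arrives and the number rises by a modest amount. Within the data shown here, compound 4 now loses that group, but the isopropoxy that enters has no counterpart among the measured compounds, so the size of the return cannot be read directly from them. A step back toward the numbers of compound 1 and compound 2 is expected, of roughly a 4.8-fold lower number from compound 3 to compound 4 (0.69 log units; beyond the scatter). For compound 4 the expected value is 20000 nM, within 8000 nM to 60000 nM.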

Compound 4, half-maximal cytotoxic concentration: 89400 nM
The estimate for compound 4 lay 4.5-fold (0.65 log units) below the measured number, and the stated range ends below it.
By their numbers in this assay, from the lowest: compounds 1 and 2 (each within the scatter of the next); then compounds 4 and 3 (each within the scatter of the next).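

At the saturated chain carbon bound to an aromatic carbon, isopropoxy and 4-methylpiperazin-1-yl are not told apart in this assay (a 1.1-fold lower number from compound 3 to compound 4 (0.03 log units; within the scatter)), so the higher numbers of this pair do not require the six-membered ring or any nitrogen in the group at this place. Isopropoxy brings a rise of similar size to the one seen with 4-methylpiperazin-1-yl, both in place of (3-hydroxypropyl)amino (a 5.9-fold higher number from compound 2 to compound 4 (0.77 log units; beyond the scatter)) and in place of methylamino (a 7.0-fold higher number from compound 1 to compound 4 (0.85 log units; beyond the scatter)). Across these four compounds, the two lower numbers go with methylamino and (3-hydroxypropyl)amino, and no compound goes against this, but nothing measured here accounts for that split.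

Open, going by these compounds, is whether dimethylamino, with no ring, falls with the higher or the lower pair. Also open, on these data alone, is where methoxy or a longer ether chain would fall at this place.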